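Notes on the amide swap from compound 2 to compound 4

The compounds below may be only part of what the source reports. "The series", "measured", "known", "first", "only" and "open" are said of these compounds alone.

Three compounds of the series have been run in an assay on isolated protein for inhibition of thyroid hormone receptor alpha (Homo sapiens), read by fluorescence polarization; on this read-out lower numbers stand for stronger inhibition and higher numbers for weaker inhibition. Compound 1 `CS(=O)(=O)c1ccc(C(=O)N2CCC(C(=O)N(Cc3ccccc3)c3ccccc3)CC2)cc1[N+](=O)[O-]` returns only a limit, > 60000 nM. Compound 2 `CS(=O)(=O)c1ccc(C(=O)N2CCC(C(=O)N3CCc4ccccc43)CC2)cc1[N+](=O)[O-]` likewise returns only a limit, > 60000 nM. Compound 3 `CS(=O)(=O)c1ccc(C(=O)NCCC(=O)N2CCc3ccccc32)cc1[N+](=O)[O-]` returns only a limit as well, > 60000 nM. For the measured compounds named here, compound 2 thus stands exactly where every measured value of the series stands, at the limit of > 60000 nM in this assay, at which 3 of the 3 values shown sit; no numbered value has been obtained for any of the three, and no measured step exists against which a new change could be set.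

Compound 4 `CN(Cc1ccccc1)C(=O)C1CCN(C(=O)c2ccc(S(C)(=O)=O)c([N+](=O)[O-])c2)CC1` is the next to be measured in this assay. It differs from compound 2 by benzyl(methyl)amino in place of 2,3-dihydro-1H-indol-1-yl on a carbonyl carbon. Going by the values given here, with three limits and no resolved step anywhere, no movement beyond the scatter is expected in either direction, and the step expected is a step that the limit leaves unreadable from compound 2 to compound 4. Compound 4 is therefore estimated to come out at 100000 nM, with a range from 40000 nM to 300000 nM, most probably reported again only as a limit.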

Compound 4, half-maximal inhibitory concentration: > 60000 nM
Compound 4: no number, only a limit; the forecaster's own chance of this, stated with the estimate: 85%; the middle value lies beyond the limit too.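

Compound 4 returns only a limit, > 60000 nM, so the steps linking it to compound 2 and compound 1 cannot be read, and the series stays where it stood: the limit of > 60000 nM in this assay, at which 4 of the 4 values shown sit.

The compounds shown leave open which structural change, if any, would give a numbered value in this assay.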